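Swapping the Aryl Group on the Ring Nitrogen of Compound 3

This account rests on a few compounds, and the source may have more. Where it says the series, first, only, none or still open, it means among the compounds named here.

Compound 1, `N#CC1=C(N)Oc2c(c3nc4ccccc4nc3c3ccccc23)C12C(=O)N(Cc1cnnn1-c1ccccc1Br)c1ccccc12`, in a functional assay on MCF7 cells (Homo sapiens) for antiproliferative activity, read by MTT assay, with a stated time of 48 h (on this read-out higher numbers stand for weaker inhibition and lower numbers for stronger inhibition), gives the limit > 50000 nM.
Compound 2, `Cc1ccc(-n2nncc2CN2C(=O)C3(C(C#N)=C(N)Oc4c3c3nc5ccccc5nc3c3ccccc43)c3ccccc32)c(C)c1`, in this assay gives the limit > 50000 nM.
Compound 3, `CCc1ccccc1-n1nncc1CN1C(=O)C2(C(C#N)=C(N)Oc3c(N)cc4nc5ccccc5nc4c32)c2ccccc21`, in this assay gives 24600 nM.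

Among the measured compounds shown here, compound 3 holds the only number among the three; the other two results are limits, as the evidence states: the limit of > 50000 nM in this assay, at which 2 of the 3 values shown sit. For the measured compounds named here, the single step between measured compounds, a step that the two limits leave unreadable from compound 1 to compound 2, is therefore unreadable and gives no scale for any change on the aromatic nitrogen.

Compound 4, `CC(=O)Nc1ccc(-n2nncc2CN2C(=O)C3(C(C#N)=C(N)Oc4c(N)cc5nc6ccccc6nc5c43)c3ccccc32)cc1`, differs from compound 3 in one place: 4-acetamidophenyl in place of 2-ethylphenyl on an aromatic nitrogen. Going by the values given here, no measured step covers this exchange, and the one step recorded cannot be read, so there is nothing to say whether such a change moves the read-out at all. On that footing the expected step in this assay, a 1.0-fold higher number from compound 3 to compound 4 (0.01 log units; within the scatter), is none beyond the scatter. Compound 4 is accordingly estimated at 25000 nM in this assay, with a range from 8000 nM to 80000 nM, and a real chance that only a limit is reported.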

Compound 4, half-maximal inhibitory concentration: > 50000 nM
Compound 4: no number, only a limit (the forecaster's own chance of this, stated with the estimate: 40%); middle value at least 2.0-fold (0.30 log units) away from the limit.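

Among the compounds shown here, the exchange on the aromatic nitrogen gives the first step at this position that can be read at all, an at least 2.0-fold higher number from compound 3 to compound 4 (0.30 log units; that floor lies within the scatter). Compound 4 gives only a limit, > 50000 nM, so this step has a floor but no upper end, and the floor alone does not separate the change from the usual scatter. The limit now covers most of the set, and compound 3 still holds the only number: the limit of > 50000 nM in this assay, at which 3 of the 4 values shown sit.

The compounds shown leave open how far compound 4 lies from compound 3, and whether the step follows from the acetamido group or from the change of aryl pattern as a whole. They also leave open how a plain phenyl group or a pyridine ring on this nitrogen of the core of compound 3 would read in this assay.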